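A methyl added to the anilino ring of compound 3

The source may report more compounds than this note shows. Statements on the series, on what has been measured and on what is new or still open speak of the compounds shown alone.

Compound 3 `COc1ccc(C(=O)c2sc(Nc3ccccc3)c(C(=O)O)c2C)cc1` is the carboxylic acid of this small series. In a functional assay, with a stated time of 150 min, tested at 20 ug/mL (a lower number here means a weaker effect, a higher number a stronger effect of the compound at the concentration tested), compound 3 gives 41.2%, the larger of the two numbers reported so far, though the step from compound 1 to compound 3 a number 8.8 percentage points higher from compound 1 to compound 3 (within the scatter) lies within the scatter. Compound 1 `COC(=O)c1c(Nc2ccccc2)sc(C(=O)c2ccc(OC)cc2)c1C` is the corresponding methyl ester and in this assay compound 1 gives 32.4%. Compound 2 `COC(=O)c1c(Nc2ccc(C)cc2)sc(C(=O)c2ccc(OC)cc2)c1C` carries the 4-methylphenyl group on the ester, and in this assay compound 2 gives "not active" (no number reported), reported without a number.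

Compound 4 `COc1ccc(C(=O)c2sc(Nc3ccc(C)cc3)c(C(=O)O)c2C)cc1` differs from compound 3 by methyl in place of hydrogen on an aromatic carbon. Among the measured compounds shown here, no measured step of this kind is available with a number at both ends. For the measured compounds named here, the only guide is the pair of compound 1 and compound 2, where the same change on the ester turns a number into a report of no activity. On that basis a drop beyond the scatter is expected, estimated as a number 29.2 percentage points lower from compound 3 to compound 4 (beyond the scatter), with a real chance that no number is reported at all. For compound 4 in this assay the activity is therefore estimated at 12%, within a range from 0% to 35%.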

Compound 4, a percentage reported as activity, at one concentration (the size of the read-out at that concentration, not a potency): "not active" (no number reported)
The entry for compound 4 holds no number; the estimate stays without a comparison.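

Among the compounds shown here, compound 4 is reported in this assay without a number, so no step from compound 3 to compound 4 can be read. No available evidence bears on this result. The compounds shown leave open how large the change from phenyl to 4-methylphenyl is, as neither the pair of compound 1 and compound 2 nor the pair of compound 3 and compound 4 has a number at both ends.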